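Compound 2 to compound 3: an azetidine amide replaces the chain

This account rests on a few compounds, and the source may have more. Where it says the series, first, only, none or still open, it means among the compounds named here.

In a functional assay on Ishikawa cells (Homo sapiens) for antiproliferative activity, read by CCK-8 assay, with a stated time of 48 h (on this read-out higher numbers stand for weaker inhibition and lower numbers for stronger inhibition), compound 1 (`CNC(=O)/C=C/CN1CC(Oc2ccc(Oc3c(-c4ccc(F)cc4)sc4cc(O)ccc34)cc2)C1`) gives > 25000 nM, which is a limit of the assay. Compound 2 (`C=C(C)C(=O)NCCOc1ccc(Oc2c(-c3ccc(F)cc3)sc3cc(O)ccc23)cc1`) gives > 25000 nM, which is likewise a limit and not a number. For the measured compounds named here, the only measured step, a step that the two limits leave unreadable from compound 1 to compound 2, therefore has no readable size. The whole evidence is the limit of > 25000 nM in this assay, at which 2 of the 2 values shown sit.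

Compound 3 (`C/C=C/C(=O)N1CC(Oc2ccc(Oc3c(-c4ccc(F)cc4)sc4cc(O)ccc34)cc2)C1`) carries 1-((prop-1-en-1-yl)carbonyl)azetidin-3-yl in place of 2-(((1-methylethenyl)carbonyl)amino)ethyl on an oxygen on an aromatic ring. Compound 1 also has an azetidin-3-yl group there, and compound 2 has none, yet both stand at the same limit. The data offer no direction for this change, so no step beyond the scatter is expected. The expected step is a number no higher from compound 2 to compound 3 (the limit leaves the size open). Compound 3 is estimated at 25000 nM, within an expected range of 8000 nM to 50000 nM.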

Compound 3, half-maximal inhibitory concentration: 9400 nM
The estimate for compound 3 lay 2.7-fold (0.42 log units) above the measured number, within the range that was stated.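

In this assay, the change to 1-((prop-1-en-1-yl)carbonyl)azetidin-3-yl on an oxygen on an aromatic ring gives the first readable number among these compounds, with an at least 2.6-fold lower number from compound 2 to compound 3 (0.42 log units; beyond the scatter). The azetidine ring alone does not separate compound 3 from the others, since compound 1 carries it too: (prop-1-en-1-yl)carbonyl in place of 3-(methylcarbamoyl)prop-2-en-1-yl on an amine nitrogen in a ring gives an at least 2.6-fold lower number from compound 1 to compound 3 (0.42 log units; beyond the scatter), so what is attached to that nitrogen makes a difference here. Both steps start from a limit, and their sizes are minimum sizes: the limit of > 25000 nM in this assay, at which 2 of the 3 values shown sit.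

The compounds shown leave open whether an acetyl group or a longer acyl chain on that nitrogen would give a similar number. They also leave open whether a piperidine ring could take the place of the azetidine.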